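Heteroaryl swap on the amino-methyl arm of compound 2

This account rests on a few compounds, and the source may have more. Where it says the series, first, only, none or still open, it means among the compounds named here.

Three compounds have numbers in a functional assay on NT2 cells (Homo sapiens) for inhibition; a lower number here means a stronger inhibitor, a higher number a weaker inhibitor. Compound 1 `CCC(C(=O)N[C@@H](CC(=O)O)C(=O)CNCN1CCCCC1)n1cc(C(C)(C)C)nc(NCc2nonc2C)c1=O` gives 0.29 nM, compound 3 `CCCCCCN(C)CNCC(=O)[C@H](CC(=O)O)NC(=O)C(CC)n1ccnc(NCc2nonc2C)c1=O` gives 0.13 nM, and compound 2 `CCC(C(=O)N[C@@H](CC(=O)O)C(=O)CSCc1ccccc1)n1ccnc(NCc2nc(C)no2)c1=O` gives 5.33 nM, the highest of the three and beyond the scatter from both others. Compound 4 `CCC(C(=O)N[C@@H](CC(=O)O)C(=O)CSCc1ccccc1)n1ccnc(NCc2cccs2)c1=O` differs from compound 2 in one place: thiophen-2-yl in place of 3-methyl-1,2,4-oxadiazol-5-yl on a saturated chain carbon bound to a nitrogen on an aromatic ring. For the measured compounds named here, no measured pair in the set carries this change, so its size is unknown here; an expected step from compound 2 to compound 4 of a 1.5-fold higher number from compound 2 to compound 4 (0.18 log units; within the scatter) rests only on the scale of the numbers seen. The estimate for compound 4 in this assay is therefore 8 nM, within a range from 2 nM to 30 nM.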

Compound 4, half-maximal inhibitory concentration: 4.56 nM
Estimate against measurement, compound 4: 1.8-fold (0.24 log units) above; measured number inside the range.
By their numbers in this assay, from the lowest: compound 3; then compound 1; then compounds 4 and 2 (each within the scatter of the next).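

In this assay, thiophen-2-yl in place of 3-methyl-1,2,4-oxadiazol-5-yl on a saturated chain carbon bound to a nitrogen on an aromatic ring gives a 1.2-fold lower number from compound 2 to compound 4 (0.07 log units; within the scatter). The number therefore does not separate these two five-membered aromatic rings, despite their different hetero atoms, with the rest of compound 2 unchanged. No supporting data bear on this result.

From the compounds shown here alone, whether a phenyl, a pyridin-2-yl or a cyclohexyl ring at this place would hold the number stays open. So does whether the same swap reads alike on a chain carrying an amine instead of the benzyl thioether.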